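This account rests on a few compounds, and the source may have more. Where it says the series, first, only, none or still open, it means among the compounds named here.

Measured compounds:
Compound 1, `CCOC(=O)c1cc2ccc(OCc3ccccc3)cc2oc1=O`, in an in vitro assay on BTI-TN-5B1-4 cells for inhibition of Amine oxidase [flavin-containing] B (Homo sapiens), read by fluorescence, with a stated time of 15 min (on this read-out higher numbers stand for weaker inhibition and lower numbers for stronger inhibition), gives 7.01 nM.
Compound 2, `CCOC(=O)c1cc2ccc(OCc3cccc(Cl)c3)cc2oc1=O`, gives 61.2 nM.
Compound 3, `O=C(NNc1ccccc1)c1cc2ccccc2oc1=O`, gives 4520 nM.

Within this small set, the only single-point step is the one between compound 1 and compound 2: an 8.7-fold higher number from compound 1 to compound 2 (0.94 log units; beyond the scatter), the change being (chloro in place of hydrogen on an aromatic carbon). Within the data shown here, compound 3 carries the highest number of the three; no step is broken down between it and compound 1 or compound 2, and the difference between the core of compound 3 and the core of compound 1 is not broken down here, so only their values can be set side by side.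

Compound 4, `O=C(NNc1ccc(Cl)cc1)c1cc2ccccc2oc1=O`, differs from compound 3 by chloro in place of hydrogen on an aromatic carbon. This is the same kind of change as that from compound 1 to compound 2, but not the same: in compound 2 the chloro sits meta to a large group, whereas in compound 4 it sits para to a large group, and the two cores differ as well.

The step from compound 3 to compound 4 is expected to be a 1.5-fold higher number from compound 3 to compound 4 (0.19 log units; within the scatter), resting on the earlier step of an 8.7-fold higher number from compound 1 to compound 2 (0.94 log units; beyond the scatter). The place and the core are not the same, so that earlier step is read with caution. Compound 4 is accordingly estimated at 7000 nM, with a plausible range from 1800 nM to 27000 nM.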

Compound 4, half-maximal inhibitory concentration: 1190 nM
Beside the measured number, compound 4's estimate is 5.9-fold (0.77 log units) above it; measured number outside the range, below it.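

In this assay, chloro in place of hydrogen on an aromatic carbon, here phenyl to 4-chlorophenyl, gives a 3.8-fold lower number from compound 3 to compound 4 (0.58 log units; beyond the scatter), so on this core the change goes with stronger inhibition. Set beside the earlier step, the same change runs in the opposite direction on the other core, and the gap between the two steps is larger than scatter alone would explain: the same change on two cores in this assay, an 8.7-fold higher number (0.94 log units; beyond the scatter) from compound 1 to compound 2 and a 3.8-fold lower number (0.58 log units; beyond the scatter) from compound 3 to compound 4, 33-fold (1.52 log units) apart, beyond the scatter of two such steps. This shows that neither the size nor the direction of the change carried from one core to the other in these two pairs, but it does not show what lies behind the reversal, since the two pairs differ both in the core and in where the chloro sits, and these two differences cannot be separated here.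

The compounds shown leave open whether a fluoro, a methyl or a methoxy group in the same place would follow the chloro on either core. Among these compounds, they also leave open whether chloro moved to the other place on each core would separate the part played by its place from the part played by the core, as each core offers only a single pair.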